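This account rests on a few compounds, and the source may have more. Where it says the series, first, only, none or still open, it means among the compounds named here.

The compounds compared here share one core and were all tested in a functional assay on HFF cells (Homo sapiens) for cytotoxicity; a higher number here means a weaker inhibitor, a lower number a stronger inhibitor. Compound 1 `CSc1nc(Cl)c2ccn(COCCOC(C)=O)c2n1` gives 100000 nM in this assay. Compound 2 `CSc1nc(Cl)c2ccn(COCCO)c2n1` gives 30000 nM in this assay. The step of a 3.3-fold lower number from compound 1 to compound 2 (0.52 log units; beyond the scatter) goes with hydrogen in place of acetyl on an oxygen on a saturated carbon. Compound 3 `CSc1nc(N)c2ccn(COCCO)c2n1` carries an amino group where compound 2 carries chloro. For compound 3 this assay reports only a limit, > 100000 nM, and not a number. The step of an at least 3.3-fold higher number from compound 2 to compound 3 (0.52 log units; beyond the scatter) is therefore known only as a lower bound, since compound 3 sits at the limit of > 100000 nM in this assay, at which 1 of the 3 values shown sits. Compound 3 thus stands at the weak end of the three values shown.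

Compound 4 `CS(=O)(=O)c1nc(N)c2ccn(COCCO)c2n1` is the next compound. Its change from compound 3 is methylsulfonyl in place of methylsulfanyl on an aromatic carbon. Neither of the two measured steps touches this position or this kind of group, so none of them bears on the change directly. What remains is the starting point: compound 3 already sits at the limit, so compound 4 is expected to stay near it, with the step of a number no higher from compound 3 to compound 4 (the limit leaves the size open) expected to be within the scatter. Compound 4 is estimated at 100000 nM in this assay, with a range from 30000 nM to 300000 nM.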

Compound 4, half-maximal inhibitory concentration: > 100000 nM
Compound 4 ended at the assay's limit; the forecaster's own chance of this, stated with the estimate: 70%; the middle value lies on the limit itself.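

Compound 3 and compound 4 both stand at a limit of this assay and not at a number, and no step can be read between them. The compounds shown leave open how far methylsulfonyl in place of methylsulfanyl on an aromatic carbon moves the number in this assay, or whether it moves it at all.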